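A few compounds are considered here, and "the series" means these few. Any claim that something is new, unique, unknown or untested is made for them only; others in the source may bear on it.

Series notes. The three compounds already entered share one core: compound 1 `COC(=O)c1ccc(-n2cc(CCCOS(=O)(=O)c3ccc(-c4ccccc4)cc3)nn2)cc1`, compound 2 `Cc1ccc(S(=O)(=O)OCCCc2cn(-c3cccc(F)c3)nn2)cc1` and compound 3 `Cc1ccc(S(=O)(=O)OCCCc2cn(-c3ccc(C(F)(F)F)cc3)nn2)cc1`. In a functional assay on A549 cells (Homo sapiens) for cytotoxicity, read by MTT assay, with a stated time of 48 h (a lower number here means a stronger inhibitor, a higher number a weaker inhibitor), compound 1 carries "not determined" (no result reported). Compound 2 sits at the limit of this assay, reported as > 100000 nM. Compound 3 likewise reaches only the limit of this assay, > 100000 nM. Compound 2 therefore stands at the limit of > 100000 nM in this assay, at which 2 of the 3 values shown sit, with no single number in the set to rank it against. Compound 4 `Cc1ccc(S(=O)(=O)OCCCc2cn(-c3cccc(C#N)c3)nn2)cc1` is the next entry; its change from compound 2 is cyano in place of fluoro on an aromatic carbon. Among the measured compounds shown here, no measured step between compounds exists. Compound 4 is expected to remain at the limit, a step of a number no higher from compound 2 to compound 4 (the limit leaves the size open) that is none beyond the scatter, since compound 2 sits at the limit of > 100000 nM in this assay, at which 2 of the 3 values shown sit. The estimate for compound 4 is 100000 nM, within 30000 nM to 300000 nM.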

Compound 4, half-maximal inhibitory concentration: > 100000 nM
Compound 4 was reported as a limit; the forecaster's own chance of this, stated with the estimate: 85%; the middle value lies on the limit itself.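

In this assay, among the compounds shown here, compound 2 and compound 4 both stop at a limit, so no step between them can be read. The compounds shown leave open how 3-fluorophenyl and 3-cyanophenyl compare, and whether this assay gives a single number for any compound of this series.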